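Swapping the group on the sulfonyl sulfur of compound 3

A few compounds are considered here, and "the series" means these few. Any claim that something is new, unique, unknown or untested is made for them only; others in the source may bear on it.

Measured values in an ADME assay on microsomes from liver (Homo sapiens) for pharmacokinetics, read by LC-MS, with a stated time of 60 min, tested at 1 uM; a lower number here means slower removal, a higher number faster removal of the compound
compound 1 `O=C(NCc1ccc(S(=O)(=O)c2cccc(C(F)(F)F)c2)cc1)N1Cc2ccncc2C1` gives 14 mL/min/kg
compound 2 `O=C(NCc1ccc(S(=O)(=O)c2cc(F)cc(F)c2)cc1)N1Cc2ccncc2C1` gives 8 mL/min/kg
compound 3 `CN1CCC(S(=O)(=O)c2ccc(CNC(=O)N3Cc4ccncc4C3)cc2)CC1` gives 11 mL/min/kg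

Compound 3 lies within the scatter of both other compounds in this assay and is the starting point here. The structural change to compound 4 `O=C(NCc1ccc(S(=O)(=O)N2CCC(N3CCCC3)CC2)cc1)N1Cc2ccncc2C1` is 4-(pyrrolidin-1-yl)piperidin-1-yl in place of 1-methylpiperidin-4-yl on a sulfonyl sulfur and consists of 4-(pyrrolidin-1-yl)piperidin-1-yl in place of 1-methylpiperidin-4-yl on a sulfonyl sulfur. Going by the values given here, no measured compound carries the entering group, so the evidence is indirect. Three swaps at this sulfur bear on it, namely a 1.8-fold lower number from compound 1 to compound 2 (0.24 log units; within the scatter) then a 1.3-fold lower number from compound 1 to compound 3 (0.10 log units; within the scatter) and a 1.4-fold higher number from compound 2 to compound 3 (0.14 log units; within the scatter) with none beyond the scatter. The expected step, no larger than the scatter and without a clear direction, is a 1.1-fold higher number from compound 3 to compound 4 (0.04 log units; within the scatter) in this estimate. For compound 4 the estimated value is 12 mL/min/kg with an expected range from 6 mL/min/kg to 25 mL/min/kg in this assay.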

Compound 4, clearance: 6 mL/min/kg
Estimate against measurement, compound 4: 2.0-fold (0.30 log units) above, and the stated range covers the measured number.
By their numbers in this assay, from the lowest: compounds 4, 2, 3 and 1 (each within the scatter of the next, the first and the last beyond it).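

In this assay, going by these compounds alone, the 4-(pyrrolidin-1-yl)piperidin-1-yl group gives the first swap on the sulfonyl sulfur to pass the scatter, with a 2.3-fold lower number from compound 1 to compound 4 (0.37 log units; beyond the scatter) as a modest step. The other two swaps stay within the scatter, with a 1.8-fold lower number from compound 3 to compound 4 (0.26 log units; within the scatter) and a 1.3-fold lower number from compound 2 to compound 4 (0.12 log units; within the scatter) so only the comparison with 3-(trifluoromethyl)phenyl separates the groups. Nothing measured here gives a reason for these steps.

Whether the pyrrolidine ring itself matters remains open, since no compound shown has a simple piperidin-1-yl on this sulfur. How a morpholine or an open-chain dimethylamino group would behave there is also unknown.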